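Solubility notes: from compound 3 to compound 4

The source may hold more compounds than are shown below. What is called first, only, known or untested is meant among the compounds shown, and "the series" means these compounds.

Compound 1 `COc1ccc(Nc2cc3[nH]c(-c4cccc(C(F)(F)F)c4)nc3cn2)nc1` in a physicochemical assay for solubility, using the shake flask method, in phosphate buffer, measured as kinetic solubility, with a stated time of 20 h, at pH 6.5 (a higher number here means a more soluble compound, a lower number a less soluble compound), gives < 5000 nM, a limit of the assay.
Compound 2 `FC(F)(F)c1cccc(-c2nc3cnc(Nc4ncccn4)cc3[nH]2)c1` in this assay gives < 5000 nM, a limit of the assay.
Compound 3 `Fc1cnc(Nc2cc3[nH]c(-c4cccc(C(F)(F)F)c4)nc3cn2)c(F)c1` in this assay gives < 5000 nM, a limit of the assay.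

Compound 3 therefore stands only at a limit, and no number places it against the other two. The steps a step that the two limits leave unreadable from compound 1 to compound 2, a step that the two limits leave unreadable from compound 1 to compound 3 and a step that the two limits leave unreadable from compound 2 to compound 3 stay unreadable because the limit of < 5000 nM in this assay, at which 3 of the 3 values shown sit, covers every value shown.

Compound 4 `N#Cc1ccc(Nc2cc3[nH]c(-c4cccc(C(F)(F)F)c4)nc3cn2)nc1` carries the change (5-cyanopyridin-2-yl in place of 3,5-difluoropyridin-2-yl on a nitrogen on an aromatic ring). Among the compounds with values here, no measured step gives a readable size, so no direction beyond the scatter can be drawn from them. For compound 4 the expected value in this assay is 3000 nM, within 500 nM to 9000 nM. The step from compound 3 is expected as a step that the limit leaves unreadable from compound 3 to compound 4, most probably again returned as a limit.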

Compound 4, solubility: < 5000 nM
Compound 4 was reported as a limit; the forecaster's own chance of this, stated with the estimate: 70%; the middle value is on the limit's open side.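

Within the data shown here, no step from compound 1, compound 2 or compound 3 to compound 4 can be read in this assay, because a single limit covers all four compounds: the limit of < 5000 nM in this assay, at which 4 of the 4 values shown sit. The compounds shown leave open how their solubilities compare and how large any of these changes is.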